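A few compounds are considered here, and "the series" means these few. Any claim that something is new, unique, unknown or untested is made for them only; others in the source may bear on it.

Of the compounds shown here, three have been tested in a functional assay on the whole organism (stomach) with Rattus norvegicus as the target (a higher number here means that more compound is needed for the effect, a lower number that less compound is needed), and a fourth, compound 4 `Cc1ccc(=O)n(CC(C)C(=N)S)n1`, awaits its turn there. Compound 1 `CC(Cn1ncccc1=O)C(=N)S` reached only a limit of the assay. In this assay compound 1 gives > 100 mg/kg. Compound 2 `N=C(S)CCn1ncccc1=S` gives 100 mg/kg in this assay. Compound 3 `Cc1ccc(=S)n(CCC(=N)S)n1` gives 100 mg/kg in this assay. The difference between the cores of compound 1 and compound 2 is not broken down here.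

From compound 2 to compound 3 the change is methyl in place of hydrogen on an aromatic carbon, and it made no change at the digits printed from compound 2 to compound 3 (within the scatter). Compound 4 differs from compound 1 by the same kind of change, (methyl in place of hydrogen on an aromatic carbon); the surroundings of the place differ in that the methyl is meta to a group of 6 heavy atoms rather than meta to a group of 5 heavy atoms.

Because compound 1 sits at the limit of > 100 mg/kg in this assay, at which 1 of the 3 values shown sits, any expectation for compound 4 begins from a limit rather than a number. For compound 4 the expected step is a step that the limit leaves unreadable from compound 1 to compound 4, an expectation that rests on no change at the digits printed from compound 2 to compound 3 (within the scatter). In this assay compound 4 is expected to give about 150 mg/kg, with a range from 60 mg/kg to 400 mg/kg, most likely reported as a limit again.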

Compound 4, dose for half-maximal effect: > 100 mg/kg
Compound 4 was reported as a limit; the forecaster's own chance of this, stated with the estimate: 70%; the middle value does not contradict the limit.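

Within the data shown here, compound 1 and compound 4 both stand at a limit of this assay, so the methyl in place of hydrogen on an aromatic carbon gives no step that can be read between them: the limit of > 100 mg/kg in this assay, at which 2 of the 4 values shown sit. The compounds shown leave open whether this methyl changes the dose needed with this core, and what dose either compound actually requires.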